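A few compounds are considered here, and "the series" means these few. Any claim that something is new, unique, unknown or untested is made for them only; others in the source may bear on it.

Among the compounds with values here, compound 1 `O=C(c1ccccc1)c1ccc(NS(=O)(=O)c2ccc(Cl)cc2Cl)cc1` is the only compound here with a numerical result. In an assay on CHO cells for binding affinity to integrin alpha-1 (Homo sapiens), read by WST assay, with a stated time of 2 h (a lower number here means that less compound is needed, a higher number that more compound is needed for the effect), compound 1 gives 20000 nM, a weak effect that needs a large amount of compound. Compound 2 `CN(c1ccc(C(=O)c2ccccc2)cc1)S(=O)(=O)c1ccc(Cl)cc1Cl` is reported in this assay as "not active" (no number reported), so no number stands beside it. Compound 3 `O=C(c1ccccc1)c1ccc(NS(=O)(=O)c2ccc(Br)cc2)cc1` has not yet been measured. It differs from compound 1 in one place: 4-bromophenyl in place of 2,4-dichlorophenyl on a sulfonyl sulfur. Within the data shown here, no pair of measured compounds shows what such an exchange does, so there is no measured step to lean on. With a single number available, the change is expected to be small, either within the usual scatter or slightly toward a weaker effect, as expressed by a 1.5-fold higher number from compound 1 to compound 3 (0.18 log units; within the scatter). Compound 3 is therefore expected to give about 30000 nM in this assay, with a plausible range from 10000 nM to 100000 nM.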

Compound 3, half-maximal effective concentration: "not active" (no number reported)
For compound 3 the study gives words and no number; there is nothing to compare the estimate with.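

Within the data shown here, compound 3 is reported in this assay in words only, so no step from compound 1 to compound 3 can be read. On these data alone, what exchanging 2,4-dichlorophenyl for 4-bromophenyl does to the number stays open. No measured evidence bears on this result.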